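Chloro for methoxy on the aryl of compound 3

The compounds below may be only part of what the source reports. "The series", "measured", "known", "first", "only" and "open" are said of these compounds alone.

Compound 3 `COc1ccc(-n2ccnc2SCC(=O)Nc2ccccc2Cl)cc1` is known in an ADME assay on MT4 cells (Homo sapiens) for cytotoxicity, read by MTT assay (a higher number here means that more compound is tolerated, a lower number that less compound is tolerated), only as a limit, > 334000 nM, the limit (the limit of > 334000 nM in this assay, at which 1 of the 3 values shown sits). Compound 1 `COc1ccc(-n2ccnc2SCC(=O)Nc2ccccc2[N+](=O)[O-])cc1` gives 161000 nM in this assay. Compound 2 `COc1ccc(-n2ccnc2SCC(=O)Nc2ccccc2C)cc1` also stands at a limit of this assay, > 353000 nM. The steps measured so far all concern the nitro, methyl and chloro groups: an at least 2.1-fold higher number from compound 1 to compound 2 (0.34 log units; beyond the scatter) and an at least 2.0-fold higher number from compound 1 to compound 3 (0.31 log units; beyond the scatter), while a step that the two limits leave unreadable from compound 2 to compound 3. Compound 4 `O=C(CSc1nccn1-c1ccc(Cl)cc1)Nc1ccccc1Cl` differs from compound 3 at a different group: chloro in place of methoxy on an aromatic carbon. Within the data shown here, none of the measured steps touches that part of the structure, so they offer no direction for this change. What compound 2 and compound 3 do show is that two such small replacements both left the read-out at a limit of this assay, and the change to compound 4 is of similar scale. For compound 4 the expected step is a step that the limit leaves unreadable from compound 3 to compound 4, a step not beyond the scatter, with the read-out most likely again reported as a limit. Compound 4 is estimated at 350000 nM, expected to lie between 180000 nM and 700000 nM.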

Compound 4, half-maximal cytotoxic concentration: > 330000 nM
Compound 4: no number, only a limit (the forecaster's own chance of this, stated with the estimate: 70%); the middle value lies beyond the limit too.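

In this assay, among these compounds, compound 4 is known only as a limit, > 330000 nM, and compound 3 also stands at a limit, so no step between the two can be read. The compounds shown leave open whether 4-chlorophenyl in place of 4-methoxyphenyl changes the read-out at all, and where the actual values of compound 2, compound 3 and compound 4 lie.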